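Trifluoromethyl Gives Way to Chloro: Expected Cell Tolerance

The source may hold more compounds than are shown below. What is called first, only, known or untested is meant among the compounds shown, and "the series" means these compounds.

Compound 1 `COc1cc2cc(Oc3ccc(NC(=O)Nc4cccc(C(F)(F)F)c4)cc3)c(C)nc2cc1OC` gives 30400 nM in a functional assay on PC-3 cells (Homo sapiens) for inhibition, read by sulforhodamine B assay, with a stated time of 48 h; a lower number here means that less compound is tolerated, a higher number that more compound is tolerated. Compound 2 `COc1cc2cc(Oc3ccc(NC(=O)Nc4ccc(Cl)c(C(F)(F)F)c4)cc3)c(C)nc2cc1OC` reaches only a limit of this assay, > 32500 nM. From the compounds shown here alone, the step of an at least 1.0-fold higher number from compound 1 to compound 2 (0.02 log units; that floor lies within the scatter) is thus capped by the limit of > 32500 nM in this assay, at which 1 of the 2 values shown sits, so its true size stays open. Compound 3 `COc1cc2cc(Oc3ccc(NC(=O)Nc4ccc(Cl)c(Cl)c4)cc3)c(C)nc2cc1OC` differs from compound 2 by chloro in place of trifluoromethyl on an aromatic carbon. Among the compounds with values here, no measured step covers this exchange, and the only measured step is small. A change no larger than the scatter is therefore expected, a number no higher from compound 2 to compound 3 (the limit leaves the size open). Compound 3 is expected to give about 32500 nM, somewhere between 15000 nM and 70000 nM, quite possibly again only as a limit.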

Compound 3, concentration lethal to 50% of the cells: 21300 nM
Beside the measured number, compound 3's estimate is 1.5-fold (0.18 log units) above it; low and high end bracket the measured number.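

From the compounds shown here alone, on this aromatic carbon, ortho to a chloro group, chloro in place of trifluoromethyl gives an at least 1.5-fold lower number from compound 2 to compound 3 (0.18 log units; that floor lies within the scatter) in this assay, and its true size stays open because compound 2 stands only at a limit: the limit of > 32500 nM in this assay, at which 1 of the 3 values shown sits. Unlike compound 2, compound 3 gives a plain number rather than a limit, which allows a full comparison with compound 1. That comparison reads a 1.4-fold lower number from compound 1 to compound 3 (0.15 log units; within the scatter), so the added chloro together with this exchange leaves the number within the scatter.

Going by these compounds, whether an amine or a carboxylic acid on this carbon would move the number beyond the scatter stays open.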